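Compound 1 to compound 4: changing the nitrogen substituent

A few compounds are considered here, and "the series" means these few. Any claim that something is new, unique, unknown or untested is made for them only; others in the source may bear on it.

In a physicochemical assay for lipophilicity, read by HPLC, at pH 7.5 (a lower number here means a more polar compound, a higher number a more lipophilic compound), compound 1 `CCOc1ccccc1-c1ccc(-c2nc3cnccc3c(N[C@H](CC)C(=O)NS(=O)(=O)C3CC3)c2C#N)cc1` gives 2.3. Compound 1 lies within the scatter of compound 2 `CC[C@@H](Nc1c(C#N)c(-c2ccc(-c3cnccc3C)cc2)nc2cnccc12)C(N)=O` at 2 and of compound 3 `CC[C@@H](Nc1c(C#N)c(-c2ccc(-c3cccc(CO)c3)cc2)nc2cnccc12)C(N)=O` at 2.

Compound 4 `CCOc1ccccc1-c1ccc(-c2nc3cnccc3c(NC(C(N)=O)C3CC3)c2C#N)cc1` differs from compound 1 by one change: a group of 7 heavy atoms (5 carbon, 1 nitrogen, 1 oxygen; one three-membered non-aromatic ring of carbon only) in place of a group of 12 heavy atoms (7 carbon, 1 nitrogen, 3 oxygen, 1 sulfur; one three-membered non-aromatic ring of carbon only), on a nitrogen on an aromatic ring. Among the compounds with values here, the only measured step, no change at the digits printed from compound 2 to compound 3 (within the scatter), concerns 3-(hydroxymethyl)phenyl in place of 4-methylpyridin-3-yl, so it stays within the scatter and does not test this change. The evidence is indirect. Compound 2 at 2 and compound 3 at 2 contain no sulfur, but each also carries a different aromatic group from compound 1. Compound 4 likewise contains no sulfur, yet it keeps the aromatic group of compound 1, a combination not yet measured. On this judgement, the expected step is a number 1.10 log units higher from compound 1 to compound 4 (beyond the scatter), upward and beyond the scatter. For compound 4 the estimated value is 3.4, with an expected range of 2.7 to 4.1.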

Compound 4, distribution coefficient: 3
Estimate against measurement, compound 4: 0.40 log units above; measured number inside the range.
By their numbers in this assay, from the lowest: compounds 2, 3 and 1 (each within the scatter of the next); then compound 4.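

In this assay, within the data shown here, the substituent on a nitrogen on an aromatic ring is a place where one change moves the number beyond the scatter, as a number 0.70 log units higher from compound 1 to compound 4 (beyond the scatter) shows, whereas the only earlier step, no change at the digits printed from compound 2 to compound 3 (within the scatter), concerned a different place. The group that leaves has 12 heavy atoms including sulfur and the group that enters has 7 without sulfur, while both keep a three-membered non-aromatic ring of carbon only, so this single step covers several differences at once and does not separate them. No measurement here bears on the cause of the step.

The compounds shown leave open how a carboxylic acid or an amine in this place would read in this assay, and which part of the leaving group accounts for the step. They also leave open whether the same change gives a step of similar size with the aromatic groups of compound 2 or compound 3.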